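The compounds below may be only part of what the source reports. "The series", "measured", "known", "first", "only" and "open" are said of these compounds alone.

Measured so far in a functional assay on the whole organism (strain Wistar) for inhibition, with Rattus norvegicus as the target, read by paw edema, with stated times of 60 min and 1 h, at a dose of 100 mg/kg by the oral route; a lower number here means less inhibition, a higher number more inhibition at the dose given (going by the name of the read-out):

Compound 1 `COc1cc2c(cc1OC)C(CC(N)=O)CC2`: 18.8%
Compound 2 `CCN(CC)C(=O)CC1CCc2cc(OC)c(OC)cc21`: 31.3%

Among the measured compounds shown here, compound 2 stands highest of the two numbers; its nearest neighbour is compound 1, and the one step recorded, a number 12.5 percentage points higher from compound 1 to compound 2 (beyond the scatter), lies beyond the scatter and is modest in size. For the measured compounds named here, that step exchanges the group on the amide nitrogen and is therefore the only measured change that bears on the present one.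

Compound 3 `CCCCNC(=O)CC1CCc2cc(OC)c(OC)cc21` differs from compound 2 in the same place: butylamino in place of diethylamino on a carbonyl carbon. The two share every atom, joined differently, and the entering butylamino brings one hydrogen-bond donor where diethylamino had none. Going by the values given here, the single step from compound 1 to compound 2 shows that the amide substituent can move the number in this assay, but it does not show whether a secondary amide of this kind sits nearer compound 1 or compound 2. The expected change is therefore small, a number 4.3 percentage points lower from compound 2 to compound 3 (within the scatter), with a slight lean downward toward compound 1. Compound 3 is estimated at 27%, with a range from 12% to 42%.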

Compound 3, a percentage reported as inhibition, in the whole organism at one dose (the size of the read-out at that dose, not a potency): 31.3%
Estimate against measurement, compound 3: 4.3 percentage points below; measured number inside the range.
By their numbers in this assay, from the lowest: compound 1; then compounds 2 and 3 (each within the scatter of the next).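

In this assay the exchange of diethylamino for butylamino on a carbonyl carbon gives no change at the digits printed from compound 2 to compound 3 (within the scatter) and so, at this position, the same atoms joined differently, with one hydrogen-bond donor entering, do not separate the two amides. Butyl in place of hydrogen on an amide-type nitrogen gives a number 12.5 percentage points higher from compound 1 to compound 3 (beyond the scatter) and shows that replacing one amide hydrogen is enough to rise clear of compound 1, since compound 3 keeps the other amide hydrogen and still does not differ from compound 2 beyond the scatter. No measurement at hand gives a reason for either step.

Going by these compounds, whether a shorter chain such as methylamino, a ring amine such as piperidine, or a carboxylic acid in place of the amide would stay level with compounds 2 and 3 or fall back toward compound 1 remains open. With each compound read at a single dose, the numbers also leave open whether compounds 2 and 3 would still match one another at other doses in this assay and whether the step from compound 1 would keep its size there.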